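Removing the Benzoyl Ester: From Compound 1 to Compound 4

This account rests on a few compounds, and the source may have more. Where it says the series, first, only, none or still open, it means among the compounds named here.

Of the compounds shown here, three have been measured in an assay on nucleic acid for inhibition of Nucleic Acid, read by fluorescence, tested at 100 uM; on this read-out lower numbers stand for less inhibition and higher numbers for more inhibition at the one concentration tested (going by the name of the read-out). Compound 1 `CN(Cc1cn(C2CCCCC2OC(=O)c2ccccc2)nn1)CC1CCCCC1` gives 32%, the lowest of the three numbers. In this assay compound 2 `CN(CCCc1ccccc1)Cc1cn(C2CCCCC2OC(=O)COc2ccccc2)nn1` gives 42%, which lies within the usual scatter of compound 1, while compound 3 `OC1CCCCC1n1cc(CN2CCN(c3ccccc3)CC2)nn1` gives 47%, a gap beyond the scatter. The unmeasured compound 4 `CN(Cc1cn(C2CCCCC2O)nn1)CC1CCCCC1` differs from compound 1 in one place: hydrogen in place of benzoyl on an oxygen on a saturated carbon. Within the data shown here, no measured pair differs in this place alone, so this kind of step has not been seen. Compound 3 also carries a hydroxy rather than a benzoyloxy, but it differs from compound 1 in other parts as well. The step of a number 6 percentage points higher from compound 1 to compound 4 (within the scatter) is expected to be small, toward more inhibition or none beyond the scatter. Compound 4 is expected to give 38%, in the range 22% to 54%.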

Compound 4, a percentage reported as inhibition, at one concentration (the size of the read-out at that concentration, not a potency): 47%
Compound 4: the middle estimate sits 9 percentage points below what was measured, and the stated range covers the measured number.
By their numbers in this assay, from the lowest: compounds 1, 2, 3 and 4 (each within the scatter of the next, the first and the last beyond it).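

This pair gives the first direct view of this position: in this assay the change from benzoyloxy to hydroxy gives a number 15 percentage points higher from compound 1 to compound 4 (beyond the scatter) while the rest of the molecule stays the same. The benzoyl group and its aromatic ring are therefore not needed for the inhibition seen with this core, and losing them does not lower the number. Nothing at hand explains why the number moves.

Still open, as far as these compounds go, is whether an acetyl or methyl group on this oxygen would behave like the hydrogen of compound 4 or the benzoyl of compound 1. From the compounds shown here alone, an amine in place of the hydroxy is equally open.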